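Fluoro on the benzamide phenyl: compound 2 to compound 3

This account rests on a few compounds, and the source may have more. Where it says the series, first, only, none or still open, it means among the compounds named here.

Among the measured compounds shown here, the two measured members share one core and a linker ending in a urea or an amide. Compound 1 `COc1cccc(-c2nn(-c3ccccc3)cc2-c2ccnc(NCCCNC(=O)Nc3ccc(Cl)c(Cl)c3)c2)c1` carries the urea end; in a functional assay on RXF 393 cells (Homo sapiens) for antiproliferative activity (a lower number here means a stronger inhibitor of growth, a higher number a weaker inhibitor of growth), compound 1 gives 1800 nM. Compound 2 `O=C(NCCCNc1cc(-c2cn(-c3ccccc3)nc2-c2cccc(O)c2)ccn1)c1ccccc1` carries the benzamide end; in this assay compound 2 gives 1970 nM. For the measured compounds named here, of the two numbers so far, compound 2 gives the higher one, but its gap to compound 1 is within the scatter, so the two are read as equal. Going by the values given here, no step between measured compounds is available, so nothing in hand shows how a change on the benzamide phenyl moves the number.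

Compound 3 `O=C(NCCCNc1cc(-c2cn(-c3ccccc3)nc2-c2cccc(O)c2)ccn1)c1ccc(F)cc1` differs from compound 2 in one place: fluoro in place of hydrogen on an aromatic carbon, a fluoro in place of hydrogen on an aromatic carbon, so that benzoyl becomes (4-fluorophenyl)carbonyl. Without a measured step of this kind, the expected step from compound 2 to compound 3 is a 1.1-fold lower number from compound 2 to compound 3 (0.04 log units; within the scatter), small and not beyond the scatter in either direction. Compound 3 is therefore estimated at 1800 nM, with a range from 900 nM to 3600 nM.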

Compound 3, concentration for 50% growth inhibition: 1630 nM
Estimate against measurement, compound 3: 1.1-fold (0.04 log units) above; low and high end bracket the measured number.
By their numbers in this assay, from the lowest: compounds 3, 1 and 2 (each within the scatter of the next).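

Working note on the benzamide phenyl: this is the first measured step at this position. In this assay, fluoro in place of hydrogen on an aromatic carbon, para to a large group, gives a 1.2-fold lower number from compound 2 to compound 3 (0.08 log units; within the scatter) and so lies inside the usual spread of repeat measurements. Phenyl and 4-fluorophenyl at the amide end of the linker therefore read as equal, and this position takes the added fluorine atom without a shift in the growth-inhibition number beyond the scatter; no measurement is at hand that could account for the size of this step.

Open, as far as these compounds go, is whether a group other than fluoro at this same place, such as an amine, a carboxylic acid or a methoxy group, moves the number beyond the scatter, and whether fluoro on another carbon of this phenyl reads the same as 4-fluorophenyl. Also open is whether this single step holds with a longer chain in the linker, since all three compounds shown carry the same linker length.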